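A few compounds are considered here, and "the series" means these few. Any claim that something is new, unique, unknown or untested is made for them only; others in the source may bear on it.

Measured so far:
compound 1 `O[C@@H]1[C@H](O)[C@@H]2C[C@@H]2[C@H]1n1cnc2c(NC3CCC3)nc(Cl)nc21`: 51.6 nM
compound 2 `O[C@@H]1[C@H](O)[C@@H]2C[C@@H]2[C@H]1n1cnc2c(NC3CCCCCC3)nc(Cl)nc21`: 230 nM

Both numbers come from an assay on CHO cells for displacement of a labelled ligand from adenosine receptor A1 (Homo sapiens), read by scintillation counting, with a stated time of 60 min; a lower number here means a stronger inhibitor, a higher number a weaker inhibitor. Compound 2 stands highest of the two; its nearest neighbour is compound 1, separated by a 4.5-fold higher number from compound 1 to compound 2 (0.65 log units; beyond the scatter), which corresponds to cycloheptyl in place of cyclobutyl on a nitrogen on an aromatic ring.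

Compound 3 `O[C@@H]1[C@H](O)[C@@H]2C[C@@H]2[C@H]1n1cnc2c(NC3CCCCCCC3)nc(Cl)nc21` has not yet been measured in this assay. It differs from compound 2 in one place: cyclooctyl in place of cycloheptyl on a nitrogen on an aromatic ring. For the measured compounds named here, the only measured step that bears on it is the one from compound 1 to compound 2, in which a larger carbon ring replaced a smaller one on the same nitrogen and the number rose beyond the scatter. The present change enlarges the same ring once more, by a smaller increment. A further rise for compound 3 is therefore expected, and it is expected to be smaller than the earlier step because a 4.5-fold higher number from compound 1 to compound 2 (0.65 log units; beyond the scatter) covered a wider change in ring size; the expected step is a 2.2-fold higher number from compound 2 to compound 3 (0.34 log units; beyond the scatter). On that basis compound 3 is estimated at 500 nM in this assay, with a range from 200 nM to 1500 nM.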

Compound 3, inhibition constant: 760 nM
Beside the measured number, compound 3's estimate is 1.5-fold (0.18 log units) below it, and the stated range covers the measured number.
By their numbers in this assay, from the lowest: compound 1; then compound 2; then compound 3.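

Enlarging the ring on the nitrogen on an aromatic ring from cycloheptyl to cyclooctyl still weakens binding in this assay, with a 3.3-fold higher number from compound 2 to compound 3 (0.52 log units; beyond the scatter) marking a further rise, so the number has not levelled off at cycloheptyl. Taken end to end, the three compounds span a 15-fold higher number from compound 1 to compound 3 (1.17 log units; beyond the scatter) and the number rises with each larger ring, with none of the three going against that order, so compound 1 with its cyclobutyl is the strongest inhibitor shown and compound 3 with its cyclooctyl the weakest. No measurement at hand explains why the larger carbon rings give higher numbers at this position.

Cyclopentyl and cyclohexyl would fill the gap between cyclobutyl and cycloheptyl, and they would show whether the rise runs evenly through the series or whether the order breaks at a middle ring size. Also open, on these data alone, is how this nitrogen tolerates groups other than plain carbon rings, such as a straight hexyl chain, a benzyl group or a cyclohexyl ring carrying a hydroxyl.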